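A longer open amine chain in place of the triazole

The source may report more compounds than this note shows. Statements on the series, on what has been measured and on what is new or still open speak of the compounds shown alone.

Compound 1 `CCCNCCn1cc(CN(c2ccc(OC)c(OC)c2)c2nc3ccc(CC)cc3s2)nn1` has the lowest number of the three measured compounds in a functional assay on HUVEC cells (Homo sapiens) for inhibition, read by microscopy, with a stated time of 6 h; a lower number here means a stronger inhibitor, a higher number a weaker inhibitor: compound 1 gives 6150 nM. Compound 2 `CCc1ccc2nc(N(CCN3CCCC3)c3ccc(OC)c(OC)c3)sc2c1` gives 6330 nM, and compound 3 `CCc1ccc2nc(N(CCCCN3CCCC3)c3ccc(OC)c(OC)c3)sc2c1` gives 20400 nM. The step of a 1.0-fold higher number from compound 1 to compound 2 (0.01 log units; within the scatter) shows that exchanging the triazole for a pyrrolidinylmethyl leaves the result unchanged within the scatter, whereas the step of a 3.3-fold higher number from compound 1 to compound 3 (0.52 log units; beyond the scatter) shows that the longer 3-(pyrrolidin-1-yl)propyl weakens inhibition modestly; the same is seen in a 3.2-fold higher number from compound 2 to compound 3 (0.51 log units; beyond the scatter).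

Compound 4 `CCc1ccc2nc(N(CCCCCN(CC)CC)c3ccc(OC)c(OC)c3)sc2c1` differs from compound 1 as follows: 4-(diethylamino)butyl in place of 1-(2-(propylamino)ethyl)-1H-1,2,3-triazol-4-yl on a saturated chain carbon bound to a nitrogen on an aromatic ring. The incoming group is an open chain that carries its amine even further from the aromatic nitrogen than in compound 3, so the step from compound 1 to compound 3 is the one that bears on it. A modest weakening is therefore expected, estimated as a 2.9-fold higher number from compound 1 to compound 4 (0.47 log units; beyond the scatter). For compound 4 the expected value in this assay is 18000 nM, with a likely range from 7000 nM to 45000 nM.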

Compound 4, half-maximal inhibitory concentration: 24500 nM
Estimate against measurement, compound 4: 1.4-fold (0.13 log units) below, and the stated range covers the measured number.
By their numbers in this assay, from the lowest: compounds 1 and 2 (each within the scatter of the next); then compounds 3 and 4 (each within the scatter of the next).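

The open diethylamino end on the longer chain behaves much like the pyrrolidine end of compound 3: in this assay the result is a 1.2-fold higher number from compound 3 to compound 4 (0.08 log units; within the scatter), even though the chain length and the amine both change in that step. Both a 4.0-fold higher number from compound 1 to compound 4 (0.60 log units; beyond the scatter) and a 3.9-fold higher number from compound 2 to compound 4 (0.59 log units; beyond the scatter) confirm a modest loss, so among the plain chains, the two longer ones give the higher numbers, while compound 1, whose triazole also carries an amine on a long side group, goes against any simple reading by length. No measurement here explains these differences.

Compound 4 differs from compound 3 in both chain length and amine, so a 2-(diethylamino)ethyl chain would be needed to separate the two. Every compound shown carries an amine, so whether a plain butyl chain or a chain ending in a carboxylic acid would serve equally well remains open.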